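Removing the methyl from the methoxy group of compound 3

A few compounds are considered here, and "the series" means these few. Any claim that something is new, unique, unknown or untested is made for them only; others in the source may bear on it.

Compound 1 `O=C(Nc1cccc(-n2cc(-c3ccncc3)c(-c3ccc(Cl)c(O)c3)n2)c1)Nc1cccc(C(F)(F)F)c1`: in a functional assay on OVCAR-8 cells (Homo sapiens) for inhibition, read by sulforhodamine B assay, with a stated time of 48 h (a lower number here means that less compound is tolerated, a higher number that more compound is tolerated), compound 1 reaches only a limit of the assay, > 32500 nM.
Compound 2 `O=C(Nc1cccc(-n2cc(-c3ccncc3)c(-c3ccc(Cl)c(O)c3)n2)c1)Nc1ccc(Cl)c(Cl)c1`: in this assay compound 2 likewise gives only a limit, > 32500 nM.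
Compound 3 `COc1cc(-c2nn(-c3cccc(NC(=O)Nc4ccc(Cl)c(C(F)(F)F)c4)c3)cc2-c2ccncc2)ccc1Cl`: in this assay compound 3 again gives only a limit, > 32500 nM.

Three ureas built on one shared core have been tested, and none returned a number; all three sit at the limit of > 32500 nM in this assay, at which 3 of the 3 values shown sit. For the measured compounds named here, the single step between two of them, 3,4-dichlorophenyl in place of 3-(trifluoromethyl)phenyl on an amide-type nitrogen, reads a step that the two limits leave unreadable from compound 1 to compound 2. Compound 3 therefore stands only at a limit, as do the other two.

Compound 4 `O=C(Nc1cccc(-n2cc(-c3ccncc3)c(-c3ccc(Cl)c(O)c3)n2)c1)Nc1ccc(Cl)c(C(F)(F)F)c1` differs from compound 3 by hydrogen in place of methyl on an oxygen on an aromatic ring, so that 4-chloro-3-methoxyphenyl becomes 4-chloro-3-hydroxyphenyl. Going by the values given here, no measured step touches this oxygen; the only step concerns the urea end and is itself unreadable. Compound 1 and compound 2 carry the same hydroxy group and both sit at the limit of > 32500 nM in this assay, at which 3 of the 3 values shown sit. The step from compound 3 to compound 4 is therefore expected to be a step that the limit leaves unreadable from compound 3 to compound 4, none beyond the scatter, with compound 4 most likely staying at the limit. Compound 4 is estimated at 40000 nM, between 15000 nM and 100000 nM.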

Compound 4, concentration lethal to 50% of the cells: > 32500 nM
Compound 4 gave a limit, no number; the forecaster's own chance of this, stated with the estimate: 80%; the middle value is on the limit's open side.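

For the compounds shown here, compound 4 gives only a limit, as do compound 1, compound 2 and compound 3, so no step among them can be read: the limit of > 32500 nM in this assay, at which 4 of the 4 values shown sit. As far as these compounds go, whether the methoxy-to-hydroxy change or the groups at the urea end alter the value at all stays open.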